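From 4-chlorophenyl to 4-hydroxyphenyl: half-life notes

The compounds below may be only part of what the source reports. "The series", "measured", "known", "first", "only" and "open" are said of these compounds alone.

Compound 2 `CC(C)(C(=O)N1CCC(CC(=O)O)CC1)C(NC(=O)c1ccc(C(=N)N)cc1)c1ccc(Cl)cc1` stands at 1.2 h in an in vivo ADME assay on the whole organism (Cavia porcellus) (on this read-out lower numbers stand for a shorter-lived compound and higher numbers for a longer-lived compound), and compound 1 `CC(C)CC(NC(=O)c1ccc(C(=N)N)cc1)C(C)(C)C(=O)N1CCC(CC(=O)O)CC1` at 0.917 h on the same read-out, so the two lie within the scatter. Within the data shown here, the only measured step, a 1.3-fold higher number from compound 1 to compound 2 (0.12 log units; within the scatter) for 4-chlorophenyl in place of isobutyl, is within the scatter. Compound 3 `CC(C)(C(=O)N1CCC(CC(=O)O)CC1)C(NC(=O)c1ccc(C(=N)N)cc1)c1ccc(O)cc1` has hydroxy in place of chloro on an aromatic carbon and remains unmeasured. Among the measured compounds shown here, no measured step alters a substituent on the aromatic ring, so the evidence is indirect. The expected change stays within the scatter, with an estimated 1.2-fold lower number from compound 2 to compound 3 (0.08 log units; within the scatter) and no firm direction. Compound 3 is expected at 1 h with 0.5 h to 2 h as its range.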

Compound 3, half-life: 1.05 h
Compound 3: middle estimate off by 1.1-fold (0.02 log units), on the low side, within the range that was stated.
By their numbers in this assay, from the lowest: compounds 1, 3 and 2 (each within the scatter of the next).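

In this assay, among these compounds, a 1.1-fold lower number from compound 2 to compound 3 (0.06 log units; within the scatter) for hydroxy in place of chloro is the only measured step on this aromatic carbon, and it lies within the scatter. The step of a 1.1-fold higher number from compound 1 to compound 3 (0.06 log units; within the scatter) for 4-hydroxyphenyl in place of isobutyl also lies within the scatter, so the half-life does not separate the three groups shown at this position. No evidence on the cause of this is at hand. Still open, going by these compounds, is whether an amine or a carboxylic acid on this aromatic carbon, or a longer chain in place of isobutyl, gives a step beyond the scatter.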